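From pyridin-4-yl to phenyl on a shared core

This account rests on a few compounds, and the source may have more. Where it says the series, first, only, none or still open, it means among the compounds named here.

Measured in an ADME assay on LLC-MK2 cells (Macaca mulatta) for cytotoxicity, read by spectrophotometry and crystal violet staining, with a stated time of 4 days; on this read-out lower numbers stand for higher toxicity in this test and higher numbers for lower toxicity in this test:
- compound 1 `CC(C)n1ncc2c(C(=O)Nc3ccccc3F)cc(-c3cccs3)nc21`: 50000 nM
- compound 2 `CC(C)n1ncc2c(C(=O)Nc3ccccc3F)cc(-c3ccncc3)nc21`: 45000 nM

Only these two compounds have been measured so far, and they share one core. Compound 2, at 45000 nM, stands within the usual scatter of compound 1, so the two cannot be ranked. The next compound, compound 3 `CC(C)n1ncc2c(C(=O)Nc3ccccc3F)cc(-c3ccccc3)nc21`, has not yet been measured. It carries phenyl in place of pyridin-4-yl on an aromatic carbon, next to the ring nitrogen: phenyl in place of pyridin-4-yl on an aromatic carbon.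

Within the data shown here, no measured step involves phenyl, so the evidence is thin. Among the measured compounds shown here, one step bears on the change, because it exchanges one aromatic ring for another at the same place: a 1.1-fold lower number from compound 1 to compound 2 (0.05 log units; within the scatter). For the measured compounds named here, with only that step as a guide, no step beyond the scatter is expected in this assay, and no direction can be favoured. The expected step is a 1.1-fold lower number from compound 2 to compound 3 (0.03 log units; within the scatter). For compound 3 the estimated value is 42000 nM, with an expected range from 18000 nM to 100000 nM.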

Compound 3, half-maximal cytotoxic concentration: > 200000 nM
Compound 3: only a limit was reported (the forecaster's own chance of this, stated with the estimate: 20%); middle value at least 4.7-fold (0.67 log units) away from the limit.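

In this assay, the group on this aromatic carbon proves able to move the read-out, which the earlier pair gave no sign of: the change to phenyl gives an at least 4.4-fold higher number from compound 2 to compound 3 (0.64 log units; beyond the scatter), and measured against the thiophen-2-yl compound it gives an at least 4.0-fold higher number from compound 1 to compound 3 (0.60 log units; beyond the scatter). Among the three compounds shown, the two rings carrying a hetero atom cannot be ranked against each other, while phenyl, the ring of carbon only, stands apart from both on the side of lower toxicity in this test. Compound 3 gives > 200000 nM, which is a limit of the assay and not a number, so both steps are minimum sizes: the limit of > 200000 nM in this assay, at which 1 of the 3 values shown sits.

The compounds shown leave open how far compound 3 truly lies from the other two, and whether the loss of the ring nitrogen is what separates phenyl from pyridin-4-yl. They also leave open how a phenyl ring bearing a methoxy group or an amine, or a saturated ring such as piperidine, would read on this same carbon.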